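The source may hold more compounds than are shown below. What is called first, only, known or untested is meant among the compounds shown, and "the series" means these compounds.

The measured compounds:
- compound 1 `O[C@H]1Cc2ccccc2C1NC1CCN(CCCc2c[nH]c3ccc(-n4cnnc4)cc23)CC1`; in an assay on CHO cells for displacement of a labelled ligand from 5-hydroxytryptamine receptor 1D (Homo sapiens) (on this read-out higher numbers stand for weaker inhibition and lower numbers for stronger inhibition), compound 1 gives 37 nM
- compound 2 `c1ccc(CNCC2CCN(CCCc3c[nH]c4ccc(-n5cnnc5)cc34)CC2)cc1`; in this assay compound 2 gives 1.6 nM
- compound 3 `CN(Cc1ccc(S(C)(=O)=O)cc1)C1CCN(CCCc2c[nH]c3ccc(-n4cnnc4)cc23)CC1`; in this assay compound 3 gives 18 nM

Among these three numbers compound 3 stands second highest. Compound 1 is nearest to it, with a somewhat higher number, and compound 2 is furthest, with a clearly lower number. All three share the same core; they differ only in what hangs on the amine nitrogen of the saturated ring.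

Compound 4 `CN(Cc1ccco1)C1CCN(CCCc2c[nH]c3ccc(-n4cnnc4)cc23)CC1` differs from compound 3 in one place: furan-2-yl in place of 4-(methylsulfonyl)phenyl on a saturated chain carbon bound to an amine nitrogen. For the measured compounds named here, the only step measured so far, a 23-fold lower number from compound 1 to compound 2 (1.36 log units; beyond the scatter), changes a different part of the molecule, the whole group on the amine nitrogen, so it gives no direct guide to swapping one aromatic ring for another at the end of that group. What remains is that compound 2, which carries a plain benzyl group, shows a lower number than compound 3, though compound 2 also lacks the methyl on the nitrogen, so the comparison is not clean.

On this thin basis compound 4 is expected to land close to compound 3, perhaps a little lower, at an estimated 10 nM with a range of 3 nM to 40 nM. This expectation corresponds to a step of a 1.8-fold lower number from compound 3 to compound 4 (0.26 log units; within the scatter).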

Compound 4, half-maximal inhibitory concentration: 9.3 nM
Beside the measured number, compound 4's estimate is 1.1-fold (0.03 log units) above it, within the range that was stated.
By their numbers in this assay, from the lowest: compound 2; then compounds 4 and 3 (each within the scatter of the next); then compound 1.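

In this assay the swap of 4-(methylsulfonyl)phenyl for furan-2-yl on a saturated chain carbon bound to an amine nitrogen gives a 1.9-fold lower number from compound 3 to compound 4 (0.29 log units; within the scatter) and so cannot be told apart from no change, even though a five-membered aromatic ring with 1 hetero atom replaces a six-membered aromatic ring of carbon only and the sulfonyl group is gone. Replacing the whole group on the saturated ring carbon counts for more in these compounds, as a 5.8-fold higher number from compound 2 to compound 4 (0.76 log units; beyond the scatter) and a 4.0-fold lower number from compound 1 to compound 4 (0.60 log units; beyond the scatter) both lie beyond the scatter, whereas the swap at the end of the group does not. Nothing given alongside these numbers explains any of the three steps.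

Still open, on these data alone, is how a plain phenyl or a thiophen-2-yl would read at this place with the methyl on the amine nitrogen kept. Also open, as far as these compounds go, is what a hydrogen in place of that methyl would do to compound 4, and whether a longer chain between the amine nitrogen and the furan-2-yl would shift the number.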